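Swapping Nitro for an Amide Chain in Compound 1

The compounds below may be only part of what the source reports. "The series", "measured", "known", "first", "only" and "open" are said of these compounds alone.

Compound 1 `Cn1c(-c2ccc([N+](=O)[O-])cc2)nc2cc(C(F)(F)F)ccc21` was tested in an ADME assay on Vero cells (Chlorocebus sabaeus) for cytotoxicity; on this read-out higher numbers stand for lower toxicity in this test and lower numbers for higher toxicity in this test. In this assay compound 1 gives > 100000 nM, which is a limit of the assay rather than a number, so its standing is known only through (the limit of > 100000 nM in this assay, at which 1 of the 3 values shown sits). Compound 2 `O=[N+]([O-])c1ccc(-c2nc3cc(C(F)(F)F)ccc3[nH]2)cc1` gives 45000 nM, and compound 3 `O=[N+]([O-])c1ccc(-c2nc3cc(C(F)(F)F)ccc3[nH]2)c([N+](=O)[O-])c1` gives 25000 nM. Hydrogen in place of methyl on an aromatic nitrogen brought an at least 2.2-fold lower number from compound 1 to compound 2 (0.34 log units; beyond the scatter), while nitro in place of hydrogen on an aromatic carbon brought a 1.8-fold lower number from compound 2 to compound 3 (0.26 log units; within the scatter). Compound 4 `CCN(CC)CC(=O)Nc1ccc(-c2nc3cc(C(F)(F)F)ccc3n2C)cc1` differs from compound 1 by (((diethylamino)methyl)carbonyl)amino in place of nitro on an aromatic carbon. Neither measured step removes a nitro, and the one that adds a nitro stayed within the scatter, so the expected step is a number no higher from compound 1 to compound 4 (the limit leaves the size open), none beyond the scatter. Compound 4 is therefore estimated at 100000 nM, between 40000 nM and 250000 nM.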

Compound 4, half-maximal cytotoxic concentration: 90000 nM
Estimate against measurement, compound 4: 1.1-fold (0.05 log units) above; low and high end bracket the measured number.
By their numbers in this assay, from the lowest: compounds 3, 2 and 4 (each within the scatter of the next, the first and the last beyond it). At a limit, above all of these: compound 1.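

In this assay, (((diethylamino)methyl)carbonyl)amino in place of nitro gives an at least 1.1-fold lower number from compound 1 to compound 4 (0.04 log units; that floor lies within the scatter). The earlier steps shown here removed a methyl or added a nitro, whereas this one takes the nitro away and puts a much larger chain at the same place, and the number in this assay stays high, so in this compound a high number does not depend on the nitro. Compound 1 stands at a limit, so the true size of this step stays open: the limit of > 100000 nM in this assay, at which 1 of the 4 values shown sits.

Going by these compounds, whether a plain amine or a carboxylic acid at this place would behave the same stays open. So does whether the same swap holds when the methyl on the aromatic nitrogen is replaced by hydrogen.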